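The compounds below may be only part of what the source reports. "The series", "measured", "known", "first", "only" and "open" are said of these compounds alone.

Measured compounds in a functional assay (cardiac atrium) for agonist activity, with Cavia porcellus as the target; on this read-out higher numbers stand for an effect only at larger amounts of compound and lower numbers for an effect already at smaller amounts:

- Compound 1, `CC1=NC(C)=C([N+](=O)[O-])C(c2ccccn2)/C1=C(\O)OC1CCCC1`, gives 19800 nM.
- Compound 2, `CC1=NC(C)=C([N+](=O)[O-])C(c2cccnc2)/C1=C(\O)OC(C)C`, gives 28500 nM.
- Compound 3, `CC1=NC(C)=C([N+](=O)[O-])C(c2ccncc2)/C1=C(\O)OC(C)C`, gives 8050 nM.

Compound 2 stands at the highest of the three numbers. Compound 1 lies within the scatter of it, so no order between compound 1 and compound 2 can be read from these values. Compound 3 is the only one set apart: the step of a 3.5-fold lower number from compound 2 to compound 3 (0.55 log units; beyond the scatter) lies beyond the scatter.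

Compound 4, `CO/C(O)=C1\C(C)=NC(C)=C([N+](=O)[O-])C1c1cccnc1`, is not yet measured. It differs from compound 2 in one place: methyl in place of isopropyl on an oxygen on an unsaturated carbon.

Within the data shown here, no measured step concerns this part of the molecule. Among the measured compounds shown here, the one step available, a 3.5-fold lower number from compound 2 to compound 3 (0.55 log units; beyond the scatter), is a change on a saturated ring carbon, not at the oxygen. Compound 1 differs from compound 2 in two places at once, so nothing can be singled out from its value. For the measured compounds named here, with no step bearing on the ester change, a move in either direction beyond the scatter is not foreseen for compound 4 in this assay.

Compound 4 is therefore expected to give about 30000 nM in this assay, within a range from 10000 nM to 90000 nM. This estimate means a step of a 1.1-fold higher number from compound 2 to compound 4 (0.02 log units; within the scatter), which is expected to stay within the scatter.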

Compound 4, half-maximal effective concentration: 70000 nM
The estimate for compound 4 lay 2.3-fold (0.37 log units) below the measured number, within the range that was stated.
By their numbers in this assay, from the lowest: compound 3; then compounds 1 and 2 (each within the scatter of the next); then compound 4.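

In this assay, among these compounds, the step of a 2.5-fold higher number from compound 2 to compound 4 (0.39 log units; beyond the scatter) is the first single change measured at the oxygen on an unsaturated carbon, and it shows that the group held there affects the read-out: with methyl in place of isopropyl, a larger amount of compound is needed for the effect. Both places changed singly so far therefore move the number beyond the scatter, and they do so in opposite directions, since the step of a 3.5-fold lower number from compound 2 to compound 3 (0.55 log units; beyond the scatter) at the saturated ring carbon goes to a lower number while the change from isopropoxy to methoxy goes to a higher one. No accompanying data bear on why the smaller group gives this result. 

With only methyl and isopropyl compared directly at this oxygen, the compounds shown leave open how the number would respond to ethyl, to a longer chain such as n-butyl, or to a chain carrying an amine. They also leave open whether the same change from isopropoxy to methoxy would move the number in the same direction on the pyridin-4-yl compound 3.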